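A few compounds are considered here, and "the series" means these few. Any claim that something is new, unique, unknown or untested is made for them only; others in the source may bear on it.

In a functional assay on DU-145 cells (Homo sapiens) for cytotoxicity, read by MTT assay (on this read-out higher numbers stand for weaker inhibition and lower numbers for stronger inhibition), compound 3 `COc1ccc2cc([C@H](C)c3nnc(SCc4c(Cl)cccc4Cl)n3-c3ccc(F)cc3)ccc2c1` gives 12300 nM, the lower of the two actual numbers, while compound 1 `COc1ccc2cc([C@H](C)c3nnc(SCc4ccc(F)cc4)n3-c3ccc(Cl)cc3)ccc2c1` gives 33600 nM, a gap beyond the scatter. Compound 2 `COc1ccc2cc([C@H](C)c3nnc(SCc4c(Cl)cccc4Cl)n3-c3cccc(Cl)c3)ccc2c1` is reported only as a limit, <= 400000 nM. Compound 4 `COc1ccc2cc([C@H](C)c3nnc(SCc4c(Cl)cccc4Cl)n3-c3ccc(Cl)cc3)ccc2c1` differs from compound 3 by chloro in place of fluoro on an aromatic carbon, para to a large group, so that 4-chlorophenyl replaces 4-fluorophenyl. Going by the values given here, the only measured step that bears on this change, a step that the limit leaves unreadable from compound 2 to compound 3, offers no size to build on. No step beyond the scatter is therefore expected in this assay, and the estimated change is a 1.2-fold higher number from compound 3 to compound 4 (0.09 log units; within the scatter). Compound 4 is estimated at 15000 nM, with an expected range of 5000 nM to 45000 nM.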

Compound 4, half-maximal inhibitory concentration: 36100 nM
For compound 4 the middle estimate is 2.4-fold (0.38 log units) below the measured one, and the stated range covers the measured number.
By their numbers in this assay, from the lowest: compound 3; then compounds 1 and 4 (each within the scatter of the next).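

Chloro in place of fluoro on the aromatic carbon gives the first readable size for this position, a 2.9-fold higher number from compound 3 to compound 4 (0.47 log units; beyond the scatter), in this assay. With 4-chlorophenyl on the aromatic nitrogen, 2,6-dichlorophenyl in place of 4-fluorophenyl on the chain carbon bound to sulfur gives a 1.1-fold higher number from compound 1 to compound 4 (0.03 log units; within the scatter). The steps from compound 2 cannot be read, because compound 2 is reported only as a limit: the limit of <= 400000 nM in this assay, at which 1 of the 4 values shown sits.

Open, from the compounds shown here alone, is how a methoxy or an amine in place of the halogen would read at this position. Also open, going by these compounds, is whether the step from fluoro to chloro keeps its size with 4-fluorophenyl on that chain carbon.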